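Reading a New Substituent Swap on Growth Inhibition

The compounds below may be only part of what the source reports. "The series", "measured", "known", "first", "only" and "open" are said of these compounds alone.

Measured so far in a functional assay on DU-145 cells (Homo sapiens) for inhibition, read by trypan blue exclusion, with a stated time of 96 h; on this read-out higher numbers stand for weaker inhibition of growth and lower numbers for stronger inhibition of growth:
- Compound 1 `COc1cc(OC)c(/C=C(/C(=O)c2ccc(Cl)cc2)S(=O)(=O)Cc2ccccc2Cl)c(OC)c1`: > 100000 nM
- Compound 2 `CCOc1ccc(/C=C(\C(=O)c2ccc(Cl)cc2)S(=O)(=O)Cc2ccc(C)cc2)cc1OC`: 10000 nM
- Compound 3 `O=C(/C(=C\c1ccc(O)c(Br)c1)Sc1ccc(Br)cc1)c1c(F)c(F)c(F)c(F)c1F`: 1000 nM

The entry for compound 1, > 100000 nM, is a limit of the assay and not a number. That leaves two true numbers to compare. Compound 3 gives 1000 nM, the lower of the two, and compound 2 gives 10000 nM, a gap well beyond the usual scatter of repeated measurements.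

Compound 4 `O=C(/C(=C\c1ccc([N+](=O)[O-])c(O)c1)Sc1ccc(Br)cc1)c1c(F)c(F)c(F)c(F)c1F` has not yet been measured in this assay. It has 3-hydroxy-4-nitrophenyl in place of 3-bromo-4-hydroxyphenyl on a double-bonded chain carbon bound to a double-bonded chain carbon. The rest of its structure matches compound 3.

Going by the values given here, no two measured compounds differ in only one place, so no measured step can guide this change. No step beyond the scatter is expected, with a slight lean towards weaker inhibition. Compound 3 already holds the lowest number here at 1000 nM, so a higher number seems the likelier direction. The expected step is a 1.5-fold higher number from compound 3 to compound 4 (0.18 log units; within the scatter). For compound 4 the estimated value is 1500 nM, with an expected range from 300 nM to 7000 nM.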

Compound 4, concentration for 50% growth inhibition: 1000 nM
Estimate against measurement, compound 4: 1.5-fold (0.18 log units) above; low and high end bracket the measured number.
By their numbers in this assay, from the lowest: compounds 3 and 4 (each within the scatter of the next); then compound 2. At a limit, above all of these: compound 1.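

Going by these compounds alone, this swap gives the first step that can be read between two compounds differing in one place in this assay, and the result is no change at the digits printed from compound 3 to compound 4 (within the scatter). The two groups are far from identical: the 3-hydroxy-4-nitrophenyl that enters has nitrogen and extra oxygen atoms and more hydrogen-bond acceptors, while the 3-bromo-4-hydroxyphenyl that leaves carries a bromine, and both keep one hydrogen-bond donor. So, on a double-bonded chain carbon bound to a double-bonded chain carbon, this one pair shows that an aromatic ring carrying quite different groups can stand in that place with no step beyond the scatter, though a single pair sets no general rule.

Going by these compounds, whether the same holds for an amine or a carboxylic acid on that ring remains open, as does what happens if a longer chain is placed there or the ring is replaced by a plain methyl group. Nothing among the measurements shown accounts for why these two groups give matching values.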